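A few compounds are considered here, and "the series" means these few. Any claim that something is new, unique, unknown or untested is made for them only; others in the source may bear on it.

Working notes on the series. Of the compounds shown here, two sharing one core have been measured in an assay on tissue (M109 cells) for inhibition of Indoleamine 2,3-dioxygenase 1 (Mus musculus), with stated times of 2 h and 18 h; a higher number here means a weaker inhibitor, a lower number a stronger inhibitor. Compound 1 `C[C@@H](CNc1ccc(Cl)cc1)[C@H]1CC[C@@H](c2ccnc3ccc(F)cc32)CC1` gives 62 nM in this assay. Compound 2 `C[C@@H](NC(=O)Nc1ccc(Cl)cc1)[C@H]1CC[C@@H](c2ccnc3ccc(F)cc32)CC1` gives 67 nM in this assay, the higher of the two numbers, though its gap to compound 1 lies within the scatter, so the two cannot be ordered. For the measured compounds named here, no single-point step between measured compounds is available, and nothing yet shows how the carbonyl-bearing side chain tolerates change.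

Compound 3 `C[C@@H](NC(=O)C1CCCCC1)[C@H]1CC[C@@H](c2ccnc3ccc(F)cc32)CC1` is the next member. It differs from compound 2 in one place: cyclohexyl in place of (4-chlorophenyl)amino on a carbonyl carbon. The aromatic ring and its hydrogen-bond donor are lost, and a saturated ring enters in their place. Going by the values given here, with no measured step to lean on, a modest weakening beyond the scatter is expected, in the direction from compound 2 to compound 3 of a 2.2-fold higher number from compound 2 to compound 3 (0.35 log units; beyond the scatter). Compound 3 is estimated at 150 nM in this assay, with a range from 50 nM to 500 nM.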

Compound 3, half-maximal inhibitory concentration: 86 nM
For compound 3 the middle estimate is 1.7-fold (0.24 log units) above the measured one, within the range that was stated.
By their numbers in this assay, from the lowest: compounds 1, 2 and 3 (each within the scatter of the next).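

In this assay, cyclohexyl in place of (4-chlorophenyl)amino on a carbonyl carbon gives a 1.3-fold higher number from compound 2 to compound 3 (0.11 log units; within the scatter), so in this pair the aromatic ring, the chlorine and the hydrogen-bond donor of the leaving group are not required to keep the number in this range. The wider change, (cyclohexylcarbonyl)amino in place of ((4-chlorophenyl)amino)methyl on a saturated chain carbon bound to a saturated chain carbon and a saturated ring carbon, gives a 1.4-fold higher number from compound 1 to compound 3 (0.14 log units; within the scatter) and likewise separates nothing. No measurement at hand bears on the basis of these results.

Open, on these data alone, is whether this tolerance extends to a primary amine, a carboxylic acid or a longer alkyl chain on the carbonyl carbon. Also open, as far as these compounds go, is whether any change at this position moves the number beyond the scatter.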